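A few compounds are considered here, and "the series" means these few. Any claim that something is new, unique, unknown or untested is made for them only; others in the source may bear on it.

Measured so far:
- Compound 1 `O=C(/C=C/c1ccccc1Cl)c1ccco1`: 12000 nM
- Compound 2 `O=C(/C=C/c1ccc(Cl)cc1)c1ccco1`: 19000 nM
- Compound 3 `CN(C)c1ccc(/C=C/C(=O)c2ccco2)cc1`: 12000 nM

All three values come from a functional assay on HL-60 cells (Homo sapiens) for inhibition, read by MTT assay, with a stated time of 48 h; a higher number here means a weaker inhibitor, a lower number a stronger inhibitor. Compound 3, at 12000 nM, shares its number with compound 1, and compound 2 sits within the usual scatter of both. These three compounds therefore cannot be ranked on these numbers.

The next compound is compound 4 `O=C(/C=C/c1ccccc1)c1ccco1`, which strips the ring substituent from compound 3: hydrogen in place of dimethylamino on an aromatic carbon. Going by the values given here, only one measured step touches this ring carbon, dimethylamino in place of chloro on an aromatic carbon, and it amounts to a 1.6-fold lower number from compound 2 to compound 3 (0.20 log units; within the scatter). Among the compounds with values here, no measured compound yet has hydrogen at this carbon, so this expectation rests on thin evidence. Still, the two groups compared there made no clear difference in this assay, so no step beyond the scatter is expected here.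

The expected step is a 1.3-fold higher number from compound 3 to compound 4 (0.10 log units; within the scatter). For compound 4 the estimated value is 15000 nM, with an expected range of 7000 nM to 32000 nM.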

Compound 4, half-maximal inhibitory concentration: 100000 nM
Beside the measured number, compound 4's estimate is 6.7-fold (0.82 log units) below it, outside the stated range (above it).
By their numbers in this assay, from the lowest: compounds 1, 3 and 2 (each within the scatter of the next); then compound 4.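

In this assay, going by these compounds alone, hydrogen in place of dimethylamino gives an 8.3-fold higher number from compound 3 to compound 4 (0.92 log units; beyond the scatter) and is the first change at this ring carbon to reach beyond the scatter, while hydrogen in place of chloro gives a 5.3-fold higher number from compound 2 to compound 4 (0.72 log units; beyond the scatter) and also an 8.3-fold higher number from compound 1 to compound 4 (0.92 log units; beyond the scatter) in the other chloro compound. The earlier comparison of dimethylamino with chloro suggested that this carbon made little difference, but the real contrast is between a substituted ring and a bare one: all three substituted compounds are stronger inhibitors than compound 4. No measurement here explains this gap.

Dimethylamino and chloro cannot be told apart in this assay, so it remains open whether any substituent would do. A methoxy group, a hydroxyl group or a carboxylic acid on this carbon would test how far that holds.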